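Swapping the aryl group on a potent antiproliferative compound

A few compounds are considered here, and "the series" means these few. Any claim that something is new, unique, unknown or untested is made for them only; others in the source may bear on it.

Measured in a functional assay on A549 cells (Homo sapiens) for antiproliferative activity, read by MTT assay, with a stated time of 72 h; on this read-out higher numbers stand for weaker inhibition and lower numbers for stronger inhibition:
Compound 1 `NC1=NC2(CCSCC2)N(OCCCOc2cc(Cl)c(Cl)cc2Cl)C(N)=N1`: > 100000 nM (a limit)
Compound 2 `NC1=NC2(CCSCC2)N(OCCCOc2ccccc2Br)C(N)=N1`: 40 nM

Of these two, only compound 2 has an exact number, at 40 nM. The entry for compound 1 is a limit, as the limit of > 100000 nM in this assay, at which 1 of the 2 values shown sits, records.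

The next compound, compound 3 `NC1=NC2(CCSCC2)N(OCCCOc2ccc(Cl)cc2)C(N)=N1`, has not been measured. Its change from compound 2 is 4-chlorophenyl in place of 2-bromophenyl on an oxygen on a saturated carbon.

One measured step alters this same place: an at least 2500-fold lower number from compound 1 to compound 2 (3.39 log units; beyond the scatter). That large step shows that the group here can matter greatly, but it involves a different pair of groups and rests on a limit. A weaker result in this assay is therefore expected, though a much smaller change than that one. The expected change is a 10-fold higher number from compound 2 to compound 3 (1.00 log units; beyond the scatter). Compound 3 is estimated at 400 nM, with an expected range of 40 nM to 5000 nM.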

Compound 3, half-maximal inhibitory concentration: 580 nM
Estimate against measurement, compound 3: 1.5-fold (0.16 log units) below, within the range that was stated.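

In this assay, the step of a 15-fold higher number from compound 2 to compound 3 (1.16 log units; beyond the scatter) shows that this position is sensitive even to a swap between two singly substituted halophenyl groups with the same heavy-atom count, not only to the loss of activity seen with compound 1. The step of an at least 170-fold lower number from compound 1 to compound 3 (2.23 log units; beyond the scatter) shows that a chlorine on this ring does not by itself bring that loss, since compound 3 keeps a measurable value while the 2,4,5-trichlorophenyl group of compound 1 does not. That step rests on a limit for compound 1: the limit of > 100000 nM in this assay, at which 1 of the 3 values shown sits.

The step from 2-bromophenyl to 4-chlorophenyl changes both the halogen and its place on the ring, so the two effects cannot be separated here; 2-chlorophenyl or 4-bromophenyl would separate them. As far as these compounds go, how a plain phenyl or a 4-methoxyphenyl would compare remains open.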